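The source may report more compounds than this note shows. Statements on the series, on what has been measured and on what is new or still open speak of the compounds shown alone.

Compound 3 `Cc1n[nH]c2nc(-c3ccc(NS(=O)(=O)c4cc(Cl)ccc4F)cc3)nc(OC3CCC(=O)CC3)c12` gives 5 nM in an assay for inhibition of serine/threonine-protein kinase Sgk1 (Homo sapiens), with stated times of 30 min and 60 min, in the presence of a further agent that is not named here; a lower number here means a stronger inhibitor, a higher number a weaker inhibitor; it stands level with compound 2 `Cc1n[nH]c2nc(-c3ccc(NS(=O)(=O)c4cc(Cl)ccc4F)cc3)nc(OC3CCOCC3)c12`, which gives 5 nM, the two together being the lowest of the three numbers, while compound 1 `CCOc1nc(-c2ccc(NS(=O)(=O)c3cc(Cl)ccc3F)cc2)nc2[nH]nc(C)c12` gives 23 nM. Compound 4 `Cc1n[nH]c2nc(-c3ccc(NS(=O)(=O)c4cc(Cl)ccc4F)cc3)nc(OCCCO)c12` differs from compound 3 in one place: 3-hydroxypropyl in place of 4-oxocyclohexyl on an oxygen on an aromatic ring. For the measured compounds named here, two measured steps bear on this: a 4.6-fold lower number from compound 1 to compound 2 (0.66 log units; beyond the scatter) and a 4.6-fold lower number from compound 1 to compound 3 (0.66 log units; beyond the scatter), both when a ring replaced the ethyl on that oxygen; by contrast, no change at the digits printed from compound 2 to compound 3 (within the scatter). Compound 4 returns to a chain, though one carrying a hydrogen-bond donor, so a modest rise toward compound 1 is expected, estimated as a 2.4-fold higher number from compound 3 to compound 4 (0.38 log units; beyond the scatter). Compound 4 is therefore expected to give about 12 nM, within 5 nM to 30 nM.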

Compound 4, half-maximal inhibitory concentration: 2 nM
For compound 4 the middle estimate is 6.0-fold (0.78 log units) above the measured one; the measured number lies below the stated range.
By their numbers in this assay, from the lowest: compound 4; then compounds 2 and 3 (each within the scatter of the next); then compound 1.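

In this assay a ring on this oxygen is not needed for a low number, as the open 3-hydroxypropyl chain brings a 2.5-fold lower number from compound 3 to compound 4 (0.40 log units; beyond the scatter) and a 2.5-fold lower number from compound 2 to compound 4 (0.40 log units; beyond the scatter), so it goes beyond both rings. Set against the ethyl, the same chain brings a 12-fold lower number from compound 1 to compound 4 (1.06 log units; beyond the scatter), the largest step yet seen at this position. No evidence given here explains these steps. The compounds shown leave open whether the hydroxyl or the chain length carries the gain. A plain propyl, a longer chain ending in hydroxyl, or a chain ending in an amine or a carboxylic acid would help separate the two.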